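Methyl in Place of Chloro on the Fused Ring

The compounds below may be only part of what the source reports. "The series", "measured", "known", "first", "only" and "open" are said of these compounds alone.

Of the compounds shown here, three built on a shared core have been measured in a functional assay on HeLa cells (Homo sapiens) for antiproliferative activity, read by MTT assay, with a stated time of 48 h; a higher number here means a weaker inhibitor, a lower number a stronger inhibitor. Compound 1 `Clc1ccc2[nH]c(-c3cn(-c4ccccc4)nc3-c3ccccc3)nc2c1` gives 3480 nM. Compound 2 `Fc1ccc(-c2nn(-c3ccccc3)cc2-c2nc3ccccc3[nH]2)cc1` gives 2330 nM. Compound 3 `Fc1ccc(-c2nn(-c3ccccc3)cc2-c2nc3cc(Cl)ccc3[nH]2)cc1` gives 2770 nM. Taken as written, compound 3 stands second highest of the three numbers, with compound 2 nearest and compound 1 furthest, yet a 1.2-fold higher number from compound 2 to compound 3 (0.08 log units; within the scatter) and a 1.3-fold lower number from compound 1 to compound 3 (0.10 log units; within the scatter) both fall within the scatter, so the three values cannot be told apart.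

Compound 4 `Cc1ccc2[nH]c(-c3cn(-c4ccccc4)nc3-c3ccc(F)cc3)nc2c1` differs from compound 3 in one place: methyl in place of chloro on an aromatic carbon. Going by the values given here, no measured step replaces a chloro with a methyl. The step that bears closest is a 1.2-fold higher number from compound 2 to compound 3 (0.08 log units; within the scatter), which introduced the chloro that now leaves and did not move the number beyond the scatter. The fluoro change, a 1.3-fold lower number from compound 1 to compound 3 (0.10 log units; within the scatter), was likewise within the scatter. The account therefore expects no shift beyond the scatter, a 1.1-fold lower number from compound 3 to compound 4 (0.03 log units; within the scatter). For compound 4 the estimate is 2600 nM, with a range from 1200 nM to 5600 nM.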

Compound 4, half-maximal inhibitory concentration: 3630 nM
Compound 4: middle estimate off by 1.4-fold (0.14 log units), on the low side, within the range that was stated.
By their numbers in this assay, from the lowest: compounds 2, 3, 1 and 4 (each within the scatter of the next).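

In this assay the direct exchange of chloro for methyl on this aromatic carbon gives a 1.3-fold higher number from compound 3 to compound 4 (0.12 log units; within the scatter) and so stays within the scatter, as does the step from hydrogen to methyl at the same place, a 1.6-fold higher number from compound 2 to compound 4 (0.19 log units; within the scatter) in this series. With the step from hydrogen to chloro also within the scatter, hydrogen, chloro and methyl at this position cannot be told apart in this assay while the rest of compound 4 is held constant. No measurement offered here explains this result.

Going by these compounds, whether an amine or a carboxylic acid on this aromatic carbon would move the number beyond the scatter remains open. Also open, on these data alone, is whether methyl at this position would give a comparable result on the core of compound 1, which lacks the fluoro.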